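The source may report more compounds than this note shows. Statements on the series, on what has been measured and on what is new or still open speak of the compounds shown alone.

Working notes on the series. Compound 2 `Cc1ccc2nc(Cl)c(/C=N/n3cc(-c4ccccc4)nc3N)cc2c1` gives 7120 nM in a functional assay on HCT-116 cells (Homo sapiens) for cytotoxicity, read by MTT assay, with a stated time of 48 h; on this read-out lower numbers stand for stronger inhibition and higher numbers for weaker inhibition. Compound 3 `COc1ccc(-c2cn(/N=C/c3cc4cc(C)ccc4nc3Cl)c(N)n2)cc1` reaches only the limit > 50000 nM in this assay, a limit and not a number. Compound 1 `Nc1nc(-c2ccc(Cl)cc2)cn1/N=C/c1cc2ccccc2nc1Cl` also sits at the limit, > 50000 nM. Among the compounds with values here, compound 3 therefore stands at the weak end of what has been measured, beside compound 1, and the one step leading into it, an at least 7.0-fold higher number from compound 2 to compound 3 (0.84 log units; beyond the scatter), is the only measured step in the set. Compound 4 `Cc1ccc2nc(Cl)c(/C=N/n3cc(-c4ccc(Cl)cc4)nc3N)cc2c1` is not yet measured in this assay; it differs from compound 3 by chloro in place of methoxy on an aromatic carbon. Within the data shown here, no measured step exchanges methoxy for chloro. Two observations bear on it: the step of an at least 7.0-fold higher number from compound 2 to compound 3 (0.84 log units; beyond the scatter), which shows that adding methoxy pushes the number up to the limit, and (the limit of > 50000 nM in this assay, at which 2 of the 3 values shown sit), where compound 1 with the same 4-chlorophenyl sits. Taking both together, the number for compound 4 is expected to stay high, with a step of an at least 1.6-fold lower number from compound 3 to compound 4 (0.22 log units; that floor lies within the scatter) that is uncertain in direction. The estimate for compound 4 is 30000 nM, with a range from 5000 nM to 100000 nM, and a limit reading remains likely.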

Compound 4, half-maximal inhibitory concentration: > 50000 nM
Compound 4: only a limit was reported (the forecaster's own chance of this, stated with the estimate: 60%); at least 1.6-fold (0.22 log units) between middle value and limit.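

In this assay, chloro in place of hydrogen at this aromatic carbon, para to a large group, gives an at least 7.0-fold higher number from compound 2 to compound 4 (0.84 log units; beyond the scatter), so the loss seen with methoxy is not unique to methoxy: compound 2, with hydrogen there, is the only compound shown with a number rather than a limit. The steps from compound 3 and from compound 1 to compound 4 join two limits and cannot be read, so 4-methoxyphenyl and 4-chlorophenyl cannot be ranked, and the methyl on the core has no readable step here. The series now gathers at one limit, which hides any further difference: the limit of > 50000 nM in this assay, at which 3 of the 4 values shown sit.

As far as these compounds go, whether fluoro, an amine or a carboxylic acid at this carbon would stay below the limit remains open. Also open, from the compounds shown here alone, is whether any replacement for hydrogen there gives a lower number than compound 2.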